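The source may hold more compounds than are shown below. What is called first, only, known or untested is meant among the compounds shown, and "the series" means these compounds.

Compound 2 `Cn1ccc2cc(-c3ccc4oc(N5Cc6ccncc6C5)nc4c3)ccc21` gives 121 nM in an assay on HEK293 cells for inhibition of Fatty-acid amide hydrolase 1 (Homo sapiens), read by fluorescence (on this read-out higher numbers stand for weaker inhibition and lower numbers for stronger inhibition), the lower of the two numbers seen so far; compound 1 `Cn1ccc2cc(-c3ccc4oc(NC5CCCCC5)nc4c3)ccc21` gives 911 nM. Among the measured compounds shown here, the only measured step, a 7.5-fold lower number from compound 1 to compound 2 (0.88 log units; beyond the scatter), shows that the site on the shared core accepts a ring-fused group with a lower number. Compound 3 `Cn1ccc2cc(-c3ccc4oc(N5CCn6cccc6C5)nc4c3)ccc21` carries a group of 9 heavy atoms (7 carbon, 2 nitrogen; one five-membered aromatic ring with 1 hetero atom, one six-membered non-aromatic ring with 2 hetero atoms) in place of a group of 9 heavy atoms (7 carbon, 2 nitrogen; one five-membered non-aromatic ring with 1 hetero atom, one six-membered aromatic ring with 1 hetero atom), on an aromatic carbon. For the measured compounds named here, no measured step compares two such ring-fused groups against each other, so for compound 3 the change is expected to stay near the scatter, a 1.2-fold higher number from compound 2 to compound 3 (0.09 log units; within the scatter). Compound 3 is therefore estimated at 150 nM, with a range from 50 nM to 500 nM.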

Compound 3, half-maximal inhibitory concentration: 42 nM
The estimate for compound 3 lay 3.6-fold (0.55 log units) above the measured number; measured number below the stated range.
By their numbers in this assay, from the lowest: compound 3; then compound 2; then compound 1.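

In this assay, this position on the shared core tells apart two groups of equal heavy-atom count: the group with a five-membered aromatic ring and a six-membered non-aromatic ring gives a 2.9-fold lower number from compound 2 to compound 3 (0.46 log units; beyond the scatter) against the group with a five-membered non-aromatic ring and a six-membered aromatic ring. Against the group with a six-membered non-aromatic ring of carbon only, it gives a 22-fold lower number from compound 1 to compound 3 (1.34 log units; beyond the scatter) and so extends the earlier step. No evidence is available that explains either step.

The compounds shown leave open which of the two rings in the entering group carries the step. They also leave open how an unfused amine such as morpholine would read at this position.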